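Working notes: piperidin-1-yl in place of pyrrolidin-1-yl

A few compounds are considered here, and "the series" means these few. Any claim that something is new, unique, unknown or untested is made for them only; others in the source may bear on it.

Measured in an ADME assay on L6 cells (Rattus norvegicus) for cytotoxicity; on this read-out higher numbers stand for weaker inhibition and lower numbers for stronger inhibition:
- Compound 1 `O=C(CN1CCCC1)OC1CC2(N3CCCCC3)CC(c3ccccc3)C1C(c1ccccc1)C2`: 16400 nM; 52000 nM (2 entries)
- Compound 2 `O=C(CN1CCC(O)CC1)OC1CC2(N3CCCCC3)CC(c3ccccc3)C1C(c1ccccc1)C2`: > 179000 nM
- Compound 3 `O=C(CCN1CCC(O)CC1)OC1CC2(N3CCCC3)CC(c3ccccc3)C1C(c1ccccc1)C2`: 35600 nM

For the measured compounds named here, compound 3, at 35600 nM, holds the only single number in this small set. Compound 1 has no single number, only (the several entries of compound 1 in this assay, 16400 nM; 52000 nM (2 entries)), and the reading for compound 3 falls inside that span. The entry for compound 2 is a limit, > 179000 nM, and not a number.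

Compound 4 `O=C(CCN1CCC(O)CC1)OC1CC2(N3CCCCC3)CC(c3ccccc3)C1C(c1ccccc1)C2` differs from compound 3 at one place on the shared core: piperidin-1-yl in place of pyrrolidin-1-yl on a saturated ring carbon. Going by the values given here, no measured pair isolates this change. Compound 1 already carries piperidin-1-yl at this place and reads 16400 nM; 52000 nM (2 entries) in this assay, a span that includes the level of compound 3. Expected is a 1.1-fold higher number from compound 3 to compound 4 (0.05 log units; within the scatter), a step within the usual scatter, with no direction favoured. Compound 4 is estimated at 40000 nM, with an expected range of 15000 nM to 110000 nM.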

Compound 4, half-maximal inhibitory concentration: 28500 nM
The estimate for compound 4 lay 1.4-fold (0.15 log units) above the measured number, within the range that was stated.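

In this assay, the swap of pyrrolidin-1-yl for piperidin-1-yl on the saturated ring carbon now has a measured pair, which gives a 1.2-fold lower number from compound 3 to compound 4 (0.10 log units; within the scatter), so the two rings read alike at this place in this pair. The entry of compound 2, > 179000 nM, is a limit and not a number. The change on the saturated chain carbon bound to a carbonyl carbon, (4-hydroxypiperidin-1-yl)methyl in place of 4-hydroxypiperidin-1-yl, gives an at least 6.2-fold lower number from compound 2 to compound 4 (0.79 log units; beyond the scatter), so of the two new steps only this one lies beyond the scatter.

On these data alone, whether the reading stays level with a morpholin-4-yl or a dimethylamino group on the same ring carbon remains open. Also open, as far as these compounds go, is whether a longer chain bearing 4-hydroxypiperidin-1-yl would move the number further.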